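Swapping methyl for fluoro on the benzamide ring

The compounds below may be only part of what the source reports. "The series", "measured", "known", "first", "only" and "open" are said of these compounds alone.

Measured so far in a functional assay on MGC-803 cells (Homo sapiens) for inhibition, read by MTT assay, with a stated time of 72 h; a higher number here means a weaker inhibitor, a lower number a stronger inhibitor:
Compound 1, `Cc1ccc(C(=O)Nc2ccc(CNC(=O)OCc3cccnc3)cc2)c(N2CCCC2)c1`, gives > 100000 nM; this is a limit of this assay, not a number.
Compound 2, `O=C(NCc1ccc(NC(=O)c2cc(F)ccc2N2CCCC2)cc1)OCc1cccnc1`, gives 10700 nM.
Compound 3, `O=C(NCc1ccc(NC(=O)c2cc(C(F)(F)F)ccc2N2CCCC2)cc1)OCc1cccnc1`, gives 42100 nM.

Compound 1 therefore stands at the weak end of what this assay can report, sitting at the limit of > 100000 nM in this assay, at which 1 of the 3 values shown sits. Compound 4, `O=C(NCc1ccc(NC(=O)c2ccc(F)cc2N2CCCC2)cc1)OCc1cccnc1`, differs from compound 1 by fluoro in place of methyl on an aromatic carbon. Going by the values given here, only one measured step exists in this set, a 3.9-fold higher number from compound 2 to compound 3 (0.59 log units; beyond the scatter), and it concerns trifluoromethyl against fluoro, not fluoro against methyl, so it does not bear directly on the present change. Compound 2, another fluoro-bearing member of the series, gives 10700 nM, which shows that a fluoro on the shared core can go with a measurable number. Compound 4 is therefore expected to land somewhere between that figure and the limit of compound 1, as an estimated step of an at least 3.3-fold lower number from compound 1 to compound 4 (0.52 log units; beyond the scatter). The estimate for compound 4 is 30000 nM, with a range from 8000 nM to 100000 nM, and a fair chance that only a limit is reported.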

Compound 4, half-maximal inhibitory concentration: 52100 nM
The estimate for compound 4 lay 1.7-fold (0.24 log units) below the measured number; measured number inside the range.
By their numbers in this assay, from the lowest: compound 2; then compounds 3 and 4 (each within the scatter of the next). At a limit, above all of these: compound 1.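

In this assay, this aromatic carbon, meta to the pyrrolidin-1-yl group and para to a large group, now has two substituents to compare, and only methyl sits at a limit of the assay rather than at a number: the limit of > 100000 nM in this assay, at which 1 of the 4 values shown sits. Fluoro in place of methyl gives an at least 1.9-fold lower number from compound 1 to compound 4 (0.28 log units; that floor lies within the scatter), so the change yields a readable value but cannot yet be called a real gain. Compound 4 gives 52100 nM, while compound 2, with its fluoro on another carbon of the same ring, gives 10700 nM.

Going by these compounds, the true distance between compound 1 and compound 4 stays open, so the full size of this step is unknown. On these data alone, it is also open whether another group on this carbon, such as an amine, a methoxy or a carboxylic acid, would give a lower number.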